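The source may hold more compounds than are shown below. What is called first, only, known or untested is meant among the compounds shown, and "the series" means these compounds.

Compound 2 `Nc1ncc(-c2cnn(C3CCNCC3)c2)cc1-c1nc2ccc(NC(=O)c3ccccc3)cc2o1` holds the highest of the two numbers measured in an assay on isolated protein for inhibition of G protein-coupled receptor kinase 5 (Homo sapiens), read by TR-FRET, with stated times of 10 min and 1 h (a higher number here means a weaker inhibitor, a lower number a stronger inhibitor), giving 3490 nM; compound 1 `Nc1ncc(-c2cnn(C3CCNCC3)c2)cc1-c1nc2ccc(-c3cn[nH]c3)cc2o1` gives 1780 nM, and the step of a 2.0-fold higher number from compound 1 to compound 2 (0.29 log units; within the scatter) lies within the scatter. Compound 3 `COc1ccc(C(=O)Nc2ccc3nc(-c4cc(-c5cnn(C6CCNCC6)c5)cnc4N)oc3c2)cc1` differs from compound 2 by methoxy in place of hydrogen on an aromatic carbon, on the six-membered aromatic ring of carbon only, para to a large group. Among the measured compounds shown here, the one measured step changes a different part of the molecule, so nothing measured bears on this change. The expected step is a 1.0-fold higher number from compound 2 to compound 3 (0.00 log units; within the scatter), nothing beyond the scatter. Compound 3 is therefore estimated at 3500 nM, with a range from 1700 nM to 7000 nM.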

Compound 3, half-maximal inhibitory concentration: 2090 nM
Beside the measured number, compound 3's estimate is 1.7-fold (0.22 log units) above it; the measured number falls inside the stated range.
By their numbers in this assay, from the lowest: compounds 1, 3 and 2 (each within the scatter of the next).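

In this assay, methoxy on the six-membered aromatic ring of carbon only, para to a large group, gives a 1.7-fold lower number from compound 2 to compound 3 (0.22 log units; within the scatter), so this first change on that ring leaves the number within the scatter. Replacing 1H-pyrazol-4-yl with ((4-methoxyphenyl)carbonyl)amino gives a 1.2-fold higher number from compound 1 to compound 3 (0.07 log units; within the scatter), so this larger group also stays within the scatter of compound 1. Nothing available explains either step. As far as these compounds go, whether an amine, a carboxylic acid or a longer alkoxy chain at this position would move the number beyond the scatter remains open.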